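Chloro Added to Compound 1: Expected Maximal Response

The source may report more compounds than this note shows. Statements on the series, on what has been measured and on what is new or still open speak of the compounds shown alone.

Measured compounds:
compound 1, `Cc1ccccc1[C@H]1COC(N)=N1`: 78%
compound 2, `NC1=N[C@@H](COCc2ccccc2)CO1`: 102%

In a functional assay on HEK293 cells for agonist activity at trace amine-associated receptor 1 (Homo sapiens), read by cAMP accumulation, with a stated time of 30 min (a higher number here means a larger maximal response, a lower number a smaller maximal response), compound 1 gives 78%, which is the lower of the two values shown. Compound 2 gives 102% in this assay, a gap to compound 1 that lies beyond the usual scatter. For the measured compounds named here, the two compounds differ in more than one place, so no single step between them can be counted; their two values are all that can be said of that pair.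

Compound 3 is `Cc1cc(Cl)ccc1[C@H]1COC(N)=N1`. It differs from compound 1 in one place: chloro in place of hydrogen on an aromatic carbon.

Going by the values given here, there is no measured pair that changes a hydrogen for a chloro on the core, so the size of this step in this assay is not known from the compounds at hand. The maximal response of compound 1 is already a large fraction of the control, and nothing measured points in either direction for this change. Compound 3 is therefore expected to show a step of a number 2 percentage points higher from compound 1 to compound 3 (within the scatter) from compound 1, that is, no change beyond the scatter. The estimate for compound 3 in this assay is 80%, with a range from 55% to 105%.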

Compound 3, largest response reached (Emax), in percent of the reference or control that the assay uses: 78%
Estimate against measurement, compound 3: 2 percentage points above, and the stated range covers the measured number.
By their numbers in this assay, from the lowest: compounds 1 and 3 (each within the scatter of the next); then compound 2.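

In this assay, chloro in place of hydrogen on an aromatic carbon, at the place meta to a methyl group and para to a group of 6 heavy atoms, gives no change at the digits printed from compound 1 to compound 3 (within the scatter). For the compounds shown here, this is the first step between compounds that differ in one place, and it shows that this carbon of the six-membered aromatic ring can carry a chloro while the maximal response stays within the scatter of that of compound 1, something the earlier pair, which differs in more than one place, could not show. The data offer no measured explanation for why this change leaves the maximal response in place.

The compounds shown leave open whether a different group at this same carbon, such as a methoxy group, an amine or a carboxylic acid, would also leave the maximal response within the scatter. They also leave open whether a chloro on another carbon of the same ring would behave as it does here, and whether this result holds for any read-out other than the largest response reached.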